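A few compounds are considered here, and "the series" means these few. Any claim that something is new, unique, unknown or untested is made for them only; others in the source may bear on it.

Compound 3, `COc1ccc(-n2ncnc2-c2cc(OC)c(OC)c(OC)c2)cc1`, is the starting point of this step. In a functional assay on HL-60 cells (Homo sapiens) for antiproliferative activity, read by MTT assay, with a stated time of 72 h (on this read-out higher numbers stand for weaker inhibition and lower numbers for stronger inhibition), compound 3 gives 6200 nM, the higher of the two numbers recorded in this assay. Compound 2, `COc1cc(-n2ncnc2-c2ccc(OC(C)C)cc2)cc(OC)c1OC`, gives 700 nM in this assay, a clearly lower number than compound 3, so compound 3 stands as the weaker of the two measured as numbers. Compound 1, `COc1cc(-n2ncnc2-c2cccc([N+](=O)[O-])c2)cc(OC)c1OC`, reaches only a limit of the assay, > 10000 nM, and is reported as such; this is noted as the limit of > 10000 nM in this assay, at which 1 of the 3 values shown sits.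

Compound 4, `COc1cc(-c2ncnn2-c2ccc(Cl)cc2Cl)cc(OC)c1OC`, has not yet been measured. It differs from compound 3 in one place: 2,4-dichlorophenyl in place of 4-methoxyphenyl on an aromatic nitrogen. Going by the values given here, no step between two measured compounds covers this exchange, so no measured precedent sets its direction, and the change from compound 3 to compound 4 in this assay is expected to lie within the scatter or only a little beyond it, toward a lower number. The estimate for compound 4 is 4000 nM, within a range from 1200 nM to 12000 nM, which would mean an expected step of a 1.6-fold lower number from compound 3 to compound 4 (0.19 log units; within the scatter).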

Compound 4, half-maximal inhibitory concentration: > 10000 nM
Compound 4: only a limit was reported; the forecaster's own chance of this, stated with the estimate: 20%; at least 2.5-fold (0.39 log units) between middle value and limit.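

On the aromatic nitrogen, 2,4-dichlorophenyl in place of 4-methoxyphenyl gives in this assay an at least 1.6-fold higher number from compound 3 to compound 4 (0.20 log units; that floor lies within the scatter). This is the first exchange shown at this position, and its direction runs toward weaker inhibition, although the step can be read only as a floor and its true size stays unknown. Compound 4 is reported only as a limit, > 10000 nM, and it shares that limit with one other compound: the limit of > 10000 nM in this assay, at which 2 of the 4 values shown sit.

The compounds shown leave open how much of this step belongs to the 2-chloro and how much to the 4-chloro substituent, since both enter together. They also leave open what a single chlorine, as in 4-chlorophenyl, or an amine on this phenyl ring would do at the same nitrogen.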